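Swapping trifluoromethyl for isopropoxy on the pyridine arm

The compounds below may be only part of what the source reports. "The series", "measured", "known", "first", "only" and "open" are said of these compounds alone.

Compound 1 `Clc1ccccc1Oc1cncc(C2=CC3CNCC(C2)C3)c1` gives 26 nM in an in vitro assay on SH-SY5Y cells for displacement of a labelled ligand from Neuronal acetylcholine receptor; alpha3/beta4 (Homo sapiens); on this read-out lower numbers stand for stronger inhibition and higher numbers for weaker inhibition.
Compound 2 `FC(F)(F)c1cncc(C2=CC3CNCC(C2)C3)c1` gives 79 nM in this assay.

Among the two measured compounds, compound 2 stands at the higher number, and the gap to compound 1 lies beyond the usual scatter of this assay. Compound 3 `CC(C)Oc1cncc(C2=CC3CNCC(C2)C3)c1` is not yet measured. It differs from compound 2 in one place: isopropoxy in place of trifluoromethyl on an aromatic carbon. Going by the values given here, no measured pair shows this exact exchange, so the size of the step can only be judged from the two numbers above. Compound 1, which carries an oxygen-linked group at the same position, gives the lower number, and isopropoxy is also oxygen-linked. The step of a 1.6-fold lower number from compound 2 to compound 3 (0.20 log units; within the scatter) is therefore expected to be small, if anything toward a lower number, and may not exceed the scatter. For compound 3 the expected value is 50 nM, with a range from 15 nM to 160 nM.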

Compound 3, inhibition constant: 4.8 nM
Estimate against measurement, compound 3: 10-fold (1.02 log units) above, and the stated range ends above it.
By their numbers in this assay, from the lowest: compound 3; then compound 1; then compound 2.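

In this assay, trifluoromethyl and isopropoxy have the same heavy-atom count, yet exchanging them on this aromatic carbon, two atoms from the ring nitrogen, gives a large step (a 16-fold lower number from compound 2 to compound 3 (1.22 log units; beyond the scatter)). The position therefore responds strongly to the identity of the group, not just to its heavy-atom count. Keeping the oxygen and changing only what it carries also matters (a 5.4-fold lower number from compound 1 to compound 3 (0.73 log units; beyond the scatter)), so an oxygen link alone does not set the number, and nothing available here explains either step.

The compounds shown cannot separate the contribution of the oxygen from that of the isopropyl group, which an isopropyl group attached directly to the ring would help to test. As far as these compounds go, how far the trend extends along a series such as methoxy, ethoxy or a longer alkoxy chain also remains open.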